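Notes on aryl variation in the shared series

This account rests on a few compounds, and the source may have more. Where it says the series, first, only, none or still open, it means among the compounds named here.

Compound 1 `N#CC1=C(N)Oc2c(c3nc4ccccc4nc3c3ccccc23)C12C(=O)N(Cc1cnnn1-c1ccc(F)cc1)c1ccccc12`, compound 2 `CCOc1ccccc1-n1nncc1CN1C(=O)C2(C(C#N)=C(N)Oc3c2c2nc4ccccc4nc2c2ccccc32)c2ccccc21` and compound 3 `CCOc1ccc(-n2nncc2CN2C(=O)C3(C(C#N)=C(N)Oc4c3c3nc5ccccc5nc3c3ccccc43)c3ccccc32)cc1` share one core and differ only in the aryl group on an aromatic nitrogen. In a functional assay on A549 cells (Homo sapiens) for antiproliferative activity, read by MTT assay, with a stated time of 48 h (on this read-out higher numbers stand for weaker inhibition and lower numbers for stronger inhibition), compound 1 gives > 50000 nM, a limit of the assay and not a number. Compound 2 also sits at a limit in this assay, giving > 50000 nM. Going by the values given here, compound 3 is the only one with a number, giving 25200 nM in this assay. Two of the three values therefore sit at the limit of > 50000 nM in this assay, at which 2 of the 3 values shown sit. The step of an at least 1.9-fold lower number from compound 1 to compound 3 (0.29 log units; that floor lies within the scatter) and the step of an at least 1.9-fold lower number from compound 2 to compound 3 (0.29 log units; that floor lies within the scatter) are floors only, and the step that the two limits leave unreadable from compound 1 to compound 2 cannot be read between two limits. Compound 4 `N#CC1=C(N)Oc2c(c3nc4ccccc4nc3c3ccccc23)C12C(=O)N(Cc1cnnn1-c1cccc(S(N)(=O)=O)c1)c1ccccc12` is to be measured in this assay and differs from compound 3 by 3-sulfamoylphenyl in place of 4-ethoxyphenyl on an aromatic nitrogen. The steps to compound 3 show that the aryl group moves the readout, but give no size. Since compound 1 and compound 2 both sit at the limit of > 50000 nM in this assay, at which 2 of the 3 values shown sit, compound 4 is expected to move back toward that limit. The expected step is a 1.6-fold higher number from compound 3 to compound 4 (0.20 log units; within the scatter). The estimated value of compound 4 is 40000 nM, within 12000 nM to 130000 nM.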

Compound 4, half-maximal inhibitory concentration: 44200 nM
The estimate for compound 4 lay 1.1-fold (0.04 log units) below the measured number; measured number inside the range.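

In this assay, compound 4 provides a second number for this aromatic nitrogen position, and the step of a 1.8-fold higher number from compound 3 to compound 4 (0.24 log units; within the scatter) shows that 3-sulfamoylphenyl and 4-ethoxyphenyl are not separated here, although the two groups differ in their counts of hydrogen-bond donors and acceptors. The steps of an at least 1.1-fold lower number from compound 2 to compound 4 (0.05 log units; that floor lies within the scatter) and an at least 1.1-fold lower number from compound 1 to compound 4 (0.05 log units; that floor lies within the scatter) are floors only, so they set compound 4 apart from neither compound 2 nor compound 1. Two of the four values remain limits and not numbers: the limit of > 50000 nM in this assay, at which 2 of the 4 values shown sit.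

The step between the two limits cannot be read, and no aryl group shown has a step printed as beyond the scatter. Still open, on these data alone, is whether a carboxylic acid or an amine on the phenyl ring, or a longer chain in place of ethoxy, would give such a step.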